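The source may report more compounds than this note shows. Statements on the series, on what has been measured and on what is new or still open speak of the compounds shown alone.

Measured so far in an ADME assay on MT4 cells (Homo sapiens) for cytotoxicity, read by MTT assay, with a stated time of 96 h; on this read-out lower numbers stand for higher toxicity in this test and higher numbers for lower toxicity in this test:

compound 1 `Cc1cccc(C2CC(c3ccc(Oc4ccccc4)cc3)=NN2c2ccc(S(N)(=O)=O)cc2)c1` gives 35000 nM
compound 2 `Cc1ccc(C2CC(c3ccc(OCc4ccccc4)cc3)=NN2c2ccc(S(N)(=O)=O)cc2)cc1` gives 35000 nM
compound 3 `NS(=O)(=O)c1ccc(N2N=C(c3ccc(Oc4ccccc4)cc3)CC2c2cccc(F)c2)cc1` gives 25000 nM

Compound 3 at 25000 nM sits within the scatter of both other compounds, so the three numbers form a single level. The next compound is compound 4 `Cc1ccc(C2CC(c3ccc(Oc4ccccc4)cc3)=NN2c2ccc(S(N)(=O)=O)cc2)cc1` with this change: 4-methylphenyl in place of 3-fluorophenyl on a saturated ring carbon. In short, 4-methylphenyl replaces 3-fluorophenyl on a saturated ring carbon, next to the ring nitrogen.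

Going by the values given here, the one measured step that bears on this is a 1.4-fold lower number from compound 1 to compound 3 (0.15 log units; within the scatter) and it is an exchange of methyl for fluoro on an aromatic carbon, the same kind of exchange run the other way. Compound 2 also carries 4-methylphenyl and gives 35000 nM on a different core. In this assay no step beyond the scatter is therefore expected, only a possible slight move toward a higher number. The expected step is a 1.3-fold higher number from compound 3 to compound 4 (0.12 log units; within the scatter) and no more. For compound 4 the estimated value is 33000 nM with an expected range of 18000 nM to 55000 nM for the coming measurement.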

Compound 4, half-maximal cytotoxic concentration: 7200 nM
For compound 4 the middle estimate is 4.6-fold (0.66 log units) above the measured one, and the stated range ends above it.
By their numbers in this assay, from the lowest: compound 4; then compounds 3, 1 and 2 (each within the scatter of the next).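

In this assay the saturated ring carbon next to the ring nitrogen no longer looks indifferent to its aryl group: 4-methylphenyl in place of 3-methylphenyl gives a 4.9-fold lower number from compound 1 to compound 4 (0.69 log units; beyond the scatter) with only the methyl shifted, and 4-methylphenyl in place of 3-fluorophenyl gives a 3.5-fold lower number from compound 3 to compound 4 (0.54 log units; beyond the scatter) at the same carbon. The 4-methylphenyl group does not set the level alone, since phenyl in place of benzyl on the oxygen gives a 4.9-fold lower number from compound 2 to compound 4 (0.69 log units; beyond the scatter) with that group held constant, so the lower number appears only with 4-methylphenyl and phenyl on the oxygen together among these compounds. Nothing at hand accounts for these steps.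

Open, going by these compounds, is whether the step follows the methyl itself or any group at that ring place, as a 4-fluorophenyl or a 4-methoxyphenyl at this carbon would show. Also open, on these data alone, is how an amine or a carboxylic acid on that phenyl would read here.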